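Methyl added to compound 2: expected inhibition of compound 3

The source may hold more compounds than are shown below. What is called first, only, known or untested is meant among the compounds shown, and "the series" means these compounds.

Measured compounds:
Compound 1 `Cc1cc(N)ccc1-c1nc2ccccc2s1`, in a functional assay on MCF7 cells (Homo sapiens) for inhibition (on this read-out higher numbers stand for weaker inhibition and lower numbers for stronger inhibition), compound 1 gives < 0.1 nM; < 0.1 nM (2 entries).
Compound 2 `Nc1ccc(-c2nc3ccccc3s2)c(Cl)c1`, in this assay compound 2 gives < 0.1 nM, a limit of the assay.

Compound 2 has only a limit and no number; it sits at the limit of < 0.1 nM in this assay, at which 1 of the 2 values shown sits. Compound 3 `Cc1cc(N)cc(Cl)c1-c1nc2ccccc2s1` differs from compound 2 by methyl in place of hydrogen on an aromatic carbon. Within the data shown here, no step between measured compounds is on hand. The step is expected to stay within the scatter, a step that the limit leaves unreadable from compound 2 to compound 3. Compound 3 is therefore estimated at 0.05 nM, with a range from 0.01 nM to 0.3 nM, and will most likely again be reported only as a limit.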

Compound 3, half-maximal inhibitory concentration: < 10 nM
Compound 3: only a limit was reported; the forecaster's own chance of this, stated with the estimate: 85%; the middle value does not contradict the limit.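

Among these compounds, compound 2 and compound 3 are both reported only as limits in this assay, and no step between them can be read. The compounds shown leave open how methyl in place of hydrogen on an aromatic carbon changes inhibition.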